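Swapping tert-butyl for cyclobutyl on a carbonyl carbon

The compounds below may be only part of what the source reports. "The series", "measured", "known", "first", "only" and "open" are said of these compounds alone.

Measured in a physicochemical assay for solubility, read by HPLC, in phosphate buffer, measured as kinetic solubility, at pH 7.4; on this read-out lower numbers stand for lower solubility and higher numbers for higher solubility:
- compound 1 `CCC(=O)c1cc(-c2ccc(S(N)(=O)=O)cc2)n(-c2ccc(Cl)cc2)n1` gives 41900 nM
- compound 2 `CC(=O)c1cc(-c2ccc(S(N)(=O)=O)cc2)n(-c2ccc(Cl)cc2)n1` gives 86800 nM
- compound 3 `CC(C)(C)C(=O)c1cc(-c2ccc(S(N)(=O)=O)cc2)n(-c2ccc(Cl)cc2)n1` gives 6600 nM

Compound 3 has the lowest number of the three. Still unmeasured, compound 4 `NS(=O)(=O)c1ccc(-c2cc(C(=O)C3CCC3)nn2-c2ccc(Cl)cc2)cc1` differs from compound 3 in one group, with cyclobutyl in place of tert-butyl on a carbonyl carbon.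

Going by the values given here, three measured steps bear on this change. Tert-butyl stands far lower than methyl (a 13-fold lower number from compound 2 to compound 3 (1.12 log units; beyond the scatter)) and modestly lower than ethyl (a 6.3-fold lower number from compound 1 to compound 3 (0.80 log units; beyond the scatter)). The smaller move between the two short chains still lies beyond the scatter (a 2.1-fold higher number from compound 1 to compound 2 (0.32 log units; beyond the scatter)). Among these compounds the number falls from methyl through ethyl to tert-butyl, and none goes against that order. Among the compounds with values here, no measured compound carries a ring on the carbonyl carbon, so this comparison is only a loose guide.

Cyclobutyl has the same carbon count as tert-butyl, so only a modest rise in this assay is expected, not a return to the level of compound 2 (86800 nM). The estimated move is modest (a 2.4-fold higher number from compound 3 to compound 4 (0.38 log units; beyond the scatter)). The expected value for compound 4 is 16000 nM (estimated range 6000 nM to 42000 nM).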

Compound 4, solubility: 17200 nM
Estimate against measurement, compound 4: 1.1-fold (0.03 log units) below; measured number inside the range.
By their numbers in this assay, from the lowest: compound 3; then compound 4; then compound 1; then compound 2.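

Tert-butyl and cyclobutyl both hold 4 heavy atoms, all carbon, yet in this assay the swap to the ring gives a clear change (a 2.6-fold higher number from compound 3 to compound 4 (0.42 log units; beyond the scatter)), so at this position the number is not set by the atom count of the group alone. Cyclobutyl still stands lower than the two short chains, both against methyl (a 5.0-fold lower number from compound 2 to compound 4 (0.70 log units; beyond the scatter)) and against ethyl (a 2.4-fold lower number from compound 1 to compound 4 (0.39 log units; beyond the scatter)), which places it between ethyl and tert-butyl. Nothing measured here explains the gap between the ring and tert-butyl.

Going by these compounds alone, only one ring size appears on the carbonyl carbon, so the standing of smaller or larger rings, such as cyclopropyl or cyclohexyl, remains open. Also open, as far as these compounds go, is what a ring containing oxygen, or an amine in place of the carbon ring, would do at this position.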